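The source may report more compounds than this note shows. Statements on the series, on what has been measured and on what is new or still open speak of the compounds shown alone.

Measured compounds:
compound 1, `N#C/N=C(\NCc1ccc(S(=O)(=O)c2ccccc2)cc1)Nc1cccnc1`, an ADME assay (liver) for metabolic stability, with Liver microsome (Homo sapiens) as the target, using microsomes, with a stated time of 30 min, tested at 1 uM; on this read-out higher numbers stand for a more stable compound and lower numbers for a less stable compound: 83%
compound 2, `N#C/N=C(\NCc1ccc(S(=O)(=O)c2cccc(C(F)(F)F)c2)cc1)Nc1ccncc1`, this assay: 62%

Compound 2 stands at the lowest of the two numbers; the nearest is compound 1, whose value lies beyond the scatter above it. Compound 3, `N#C/N=C(\NCc1ccc(S(=O)(=O)c2ccccc2)cc1)Nc1ccncc1`, has not yet been measured in this assay. It differs from compound 2 by hydrogen in place of trifluoromethyl on an aromatic carbon; the same difference, cut one bond further out, reads 3-(trifluoromethyl)phenyl to phenyl. Going by the values given here, no step between measured compounds describes this change, but compound 1, which carries the same phenyl without trifluoromethyl, gives 83%. Compound 3 is therefore expected to rise moderately, by about a number 13 percentage points higher from compound 2 to compound 3 (beyond the scatter), though the gap may fall within the scatter. The estimated value of compound 3 is 75%, in the range 60% to 90%.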

Compound 3, percent of the compound remaining: 96%
Compound 3: the middle estimate sits 21 percentage points below what was measured; measured number above the stated range.
By their numbers in this assay, from the lowest: compound 2; then compound 1; then compound 3.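

With hydrogen in place of trifluoromethyl on the aromatic carbon, this assay shows a number 34 percentage points higher from compound 2 to compound 3 (beyond the scatter) when the pyridin-4-yl stays fixed, so this position alone carries a large change, which the earlier pair, differing in two places, could not show. The other part of the structure can now also be read alone: pyridin-4-yl in place of pyridin-3-yl on an amine nitrogen gives a number 13 percentage points higher from compound 1 to compound 3 (beyond the scatter) in this assay and so a modest step, with the phenyl fixed. Nothing at hand accounts for either step.

The compounds shown place only hydrogen and trifluoromethyl at this position, so it stays open how a fluorine, a chlorine or a methoxy group there would read. On these data alone, it is also open whether the trifluoromethyl step keeps its size with pyridin-3-yl on the amine nitrogen.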